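The compounds below may be only part of what the source reports. "The series", "measured", "known", "first", "only" and "open" are said of these compounds alone.

In a functional assay on MCF7 cells (Homo sapiens) for cytotoxicity, read by MTT assay, with a stated time of 6 days (on this read-out higher numbers stand for an effect only at larger amounts of compound and lower numbers for an effect already at smaller amounts), compound 2 (`COC(=O)c1c(-c2ccc([N+](=O)[O-])cc2)oc2ccccc2c1=O`) gives > 25 ug/mL as a limit and not a number. Compound 1 (`COC(=O)c1c(-c2cc(OC)cc(OC)c2)oc2ccccc2c1=O`) gives > 25 ug/mL as a limit too. Compound 3 (`COC(=O)c1c(-c2ccc([N+](=O)[O-])cc2)oc2cc(OC)ccc2c1=O`) gives > 25 ug/mL as a limit as well. Within the data shown here, the series so far therefore reads only as the limit of > 25 ug/mL in this assay, at which 3 of the 3 values shown sit, and nothing finer.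

Compound 4 (`COC(=O)c1c(-c2ccc(O)cc2)oc2ccccc2c1=O`) differs from compound 2 by hydroxy in place of nitro on an aromatic carbon, para to a large group: hydroxy in place of nitro on an aromatic carbon and the shared core otherwise unchanged.

Among the measured compounds shown here, the one measured step is a step that the two limits leave unreadable from compound 2 to compound 3 and it is a different change, methoxy in place of hydrogen on an aromatic carbon. It offers no size to carry over, and no direction in this assay can be drawn from it. No step beyond the scatter is therefore expected, and another limit is the likeliest report. The estimate means a step that the limit leaves unreadable from compound 2 to compound 4 as the expected step. For compound 4 the estimated value is 30 ug/mL with an expected range from 12 ug/mL to 60 ug/mL in the same assay.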

Compound 4, concentration for half-maximal effect: > 25 ug/mL
Compound 4 was reported as a limit (the forecaster's own chance of this, stated with the estimate: 70%); the middle value lies beyond the limit too.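

Compound 2 and compound 4 both stand as limits, so the step between them cannot be read in this assay. The compounds shown leave open whether any change on the shared core gives a measurable value: the limit of > 25 ug/mL in this assay, at which 4 of the 4 values shown sit.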